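Swapping Methyl for Cyano on the Amide Side

The source may hold more compounds than are shown below. What is called first, only, known or untested is meant among the compounds shown, and "the series" means these compounds.

Among the compounds with values here, compound 2 `Cc1cccc(C(=O)Nc2c(C(O)(C(F)(F)F)C(F)(F)F)ccc3ccccc23)c1` gives the lowest of the two numbers measured so far in an assay on LtK cells with ATP-sensitive inward rectifier potassium channel 11 (Homo sapiens) as the target (a higher number here means that more compound is needed for the effect, a lower number that less compound is needed), namely 23 nM. Its nearest neighbour, compound 1 `O=C(Nc1c(C(O)(C(F)(F)F)C(F)(F)F)ccc2ccccc12)c1cccc(Br)c1`, gives 80 nM, and the step of a 3.5-fold lower number from compound 1 to compound 2 (0.54 log units; beyond the scatter) shows that a single group swap at this position can shift the result beyond the usual scatter. Compound 3 `N#Cc1cccc(C(=O)Nc2c(C(O)(C(F)(F)F)C(F)(F)F)ccc3ccccc23)c1` carries the change (cyano in place of methyl on an aromatic carbon). Within the data shown here, no measured step involves a cyano group, so the bromo-to-methyl step is only an indirect guide. A modest rise is expected, a 2.6-fold higher number from compound 2 to compound 3 (0.42 log units; beyond the scatter). For compound 3 the estimate is 60 nM, within a range of 15 nM to 250 nM.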

Compound 3, half-maximal effective concentration: 12 nM
Estimate against measurement, compound 3: 5.0-fold (0.70 log units) above; the whole stated range lies above it.
By their numbers in this assay, from the lowest: compounds 3 and 2 (each within the scatter of the next); then compound 1.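

Putting cyano in place of methyl at this position gives a 1.9-fold lower number from compound 2 to compound 3 (0.28 log units; within the scatter), so the two groups cannot be told apart here, even though cyano brings one hydrogen-bond acceptor that methyl lacks. Cyano in place of bromo gives a 6.7-fold lower number from compound 1 to compound 3 (0.82 log units; beyond the scatter), which sets compound 1 apart from compound 3 just as it is set apart from compound 2. No measurement at hand explains these results. The compounds shown leave open how an amine, a carboxylic acid or a longer chain would behave at this position.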